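Pyrazoline sulfonamide series: cytotoxicity notes

The compounds below may be only part of what the source reports. "The series", "measured", "known", "first", "only" and "open" are said of these compounds alone.

Measured compounds:
compound 1 `Cc1ccccc1C1CC(c2ccc(OCc3ccccc3)cc2)=NN1c1ccc(S(N)(=O)=O)cc1`, with >= 100000 nM, which is a limit of the assay.
compound 2 `NS(=O)(=O)c1ccc(N2N=C(c3ccc(OCc4ccccc4)cc3)CC2c2ccccc2)cc1`, with > 100000 nM, which is a limit of the assay.
compound 3 `NS(=O)(=O)c1ccc(N2N=C(c3ccc(Oc4ccccc4)cc3)CC2c2ccccc2)cc1`, with 42000 nM.

All numbers come from an ADME assay on MT4 cells (Homo sapiens) for cytotoxicity, read by MTT assay, with a stated time of 96 h; on this read-out lower numbers stand for higher toxicity in this test and higher numbers for lower toxicity in this test. Going by the values given here, compound 3 carries the only number in this assay; compound 1 and compound 2 each sit at a limit. The core of compound 2 becomes that of compound 3 by phenyl in place of benzyl on an oxygen on an aromatic ring, giving an at least 2.3-fold lower number from compound 2 to compound 3 (0.37 log units; beyond the scatter).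

Compound 4 `Cc1cccc(C2CC(c3ccc(Oc4ccccc4)cc3)=NN2c2ccc(S(N)(=O)=O)cc2)c1` is not yet measured. It differs from compound 3 by methyl in place of hydrogen on an aromatic carbon. The same kind of change, (methyl in place of hydrogen on an aromatic carbon), goes from compound 2 to compound 1, but there the methyl is ortho to a large group, whereas in compound 4 it is meta to a large group; that earlier step is a step that the two limits leave unreadable from compound 2 to compound 1, because both values are limits (the limit of > 100000 nM in this assay, at which 1 of the 3 values shown sits, (the limit of >= 100000 nM in this assay, at which 1 of the 3 values shown sits)). The earlier step therefore gives no size to lean on. In this assay compound 4 is expected to stay near compound 3, an estimated 1.2-fold lower number from compound 3 to compound 4 (0.08 log units; within the scatter). Compound 4 is estimated at 35000 nM, between 15000 nM and 100000 nM.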

Compound 4, half-maximal cytotoxic concentration: 35000 nM
Estimate against measurement, compound 4: no gap at the digits printed, within the range that was stated.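

In this assay, methyl in place of hydrogen on an aromatic carbon, here phenyl to 3-methylphenyl, gives a 1.2-fold lower number from compound 3 to compound 4 (0.08 log units; within the scatter), so on the core of compound 3 this change shows no effect beyond the scatter. The same change from compound 2 to compound 1 cannot be read: both ends are limits of the assay. This leaves a single readable step, at a single place, and it does not show whether the result carries from one core to the other.

Still open, going by these compounds, is whether an amine or a carboxylic acid in place of that methyl would move the number beyond the scatter in this assay. On these data alone, a longer chain on the same aromatic carbon also remains open.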